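Swapping the anilide ring of compound 3 for a dimethylpyridine

This account rests on a few compounds, and the source may have more. Where it says the series, first, only, none or still open, it means among the compounds named here.

Of the compounds shown here, three of a shared core have been measured in a physicochemical assay for solubility, in phosphate buffer, measured as kinetic solubility, with a stated time of 1 h, at pH 7.4; a higher number here means a more soluble compound, a lower number a less soluble compound. Compound 1 `Cc1cc(C)cc(NC(=O)COc2cc(C)nc3ccc(F)cc23)c1` gives 28000 nM. Compound 2 `COc1ccc2nc(C)cc(OC3CCN(c4ccccc4)C3=O)c2c1` gives 215000 nM, and compound 3 `COc1ccc2nc(C)cc(OCC(=O)Nc3cccc(C)c3)c2c1` gives 193000 nM. Compound 3 thus stands second highest of the three numbers; its nearest neighbour is compound 2, whose number sits within the scatter of compound 3, so no order can be read between those two, while compound 1 lies furthest off, with a number well below that of compound 3 and beyond the scatter.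

Compound 4 `COc1ccc2nc(C)cc(OCC(=O)Nc3c(C)cncc3C)c2c1` has not yet been measured in this assay. It differs from compound 3 in one place: 3,5-dimethylpyridin-4-yl in place of 3-methylphenyl on an amide-type nitrogen. Within the data shown here, no measured pair shows this step, so its size can only be guessed. The expectation is a modest rise in this assay, possibly no larger than the scatter, so that the step of a 1.8-fold higher number from compound 3 to compound 4 (0.26 log units; within the scatter) is estimated as small and upward. Compound 4 is therefore expected to give about 350000 nM, in a range from 150000 nM to 800000 nM.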

Compound 4, solubility: 12000 nM
Compound 4: the middle estimate sits 29-fold (1.46 log units) above what was measured; measured number below the stated range.
By their numbers in this assay, from the lowest: compound 4; then compound 1; then compounds 3 and 2 (each within the scatter of the next).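

In this assay, among these compounds, the place on the amide-type nitrogen proves far from neutral: 3,5-dimethylpyridin-4-yl in place of 3-methylphenyl gives a 16-fold lower number from compound 3 to compound 4 (1.21 log units; beyond the scatter), the only measured step at this place and one well beyond the scatter. The entering group brings one ring nitrogen and one hydrogen-bond acceptor that the leaving group lacks, yet the number falls, so in this single pair the added acceptor does not go with a higher reading. Nothing at hand bears on why the number falls so far.

Still open, going by these compounds, is whether the fall follows the ring nitrogen or the second methyl group, which an unsubstituted pyridin-4-yl on the same nitrogen would help to separate. Also open, on these data alone, is whether a step of this size would recur on the core of compound 1.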